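Cytotoxicity Limits and an Expected Aminomethyl Analogue

This account rests on a few compounds, and the source may have more. Where it says the series, first, only, none or still open, it means among the compounds named here.

Compound 1 `CCCCc1c(F)c(N)c2c(=O)cc(-c3ccc(N)c(F)c3)oc2c1F` and compound 2 `CCOC(=O)c1c(F)c(N)c2c(=O)cc(-c3ccc(N)c(F)c3)oc2c1F` share one core and differ in a single group. In a functional assay on HeLa cells (Homo sapiens) for cytotoxicity, read by neutral red uptake, with a stated time of 3 days (on this read-out higher numbers stand for weaker inhibition and lower numbers for stronger inhibition), compound 1 gives > 100000 nM, which is a limit of the assay. In this assay compound 2 likewise gives > 100000 nM, again a limit. The step that the two limits leave unreadable from compound 1 to compound 2 is therefore not readable. Compound 3 `CN(C)Cc1c(F)c(N)c2c(=O)cc(-c3ccc(N)c(F)c3)oc2c1F` differs from compound 2 by (dimethylamino)methyl in place of ethoxycarbonyl on an aromatic carbon. Within the data shown here, because the limit of > 100000 nM in this assay, at which 2 of the 2 values shown sit, no measured step offers a size or direction, so compound 3 is expected to show no change beyond the scatter, an estimated step that the limit leaves unreadable from compound 2 to compound 3. Compound 3 is estimated in this assay at 150000 nM, within 50000 nM to 500000 nM.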

Compound 3, half-maximal inhibitory concentration: 8900 nM
For compound 3 the middle estimate is 17-fold (1.23 log units) above the measured one; measured number outside the range, below it.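

Among these compounds, compound 3 gives the only readable value of the three in this assay, which shows that the group on this aromatic carbon, ortho to two fluoro groups, can move the read-out: the record holds an at least 11-fold lower number from compound 2 to compound 3 (1.05 log units; beyond the scatter) as well as an at least 11-fold lower number from compound 1 to compound 3 (1.05 log units; beyond the scatter). Both steps are bounds rather than exact sizes, since the other two compounds rest at a limit: the limit of > 100000 nM in this assay, at which 2 of the 3 values shown sit.

From the compounds shown here alone, whether an aminomethyl or a morpholinomethyl group on this carbon would give a similar number stays open, as does what a carboxylic acid there would give.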